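The source may report more compounds than this note shows. Statements on the series, on what has been measured and on what is new or still open speak of the compounds shown alone.

Compound 1 `Cc1noc(C)c1NC(=O)N1CCC(c2nc(-c3ccc4ccccc4n3)no2)CC1` sits at the weak end of the three compounds measured in a functional assay on Shh Light II cells (Mus musculus) for inhibition, read by a luciferase reporter; on this read-out lower numbers stand for stronger inhibition and higher numbers for weaker inhibition: compound 1 gives 3000 nM, the highest number of the set. Compound 2 `O=C(CC1CCCCCC1)N1CCC(c2nc(-c3ccc4ccccc4n3)no2)CC1` gives 840 nM in this assay, and compound 3 `COc1ccccc1OC(=O)N1CCC(c2nc(-c3ccc4ccccc4n3)no2)CC1` gives 250 nM. Both steps away from compound 1 lower the number: a 3.6-fold lower number from compound 1 to compound 2 (0.55 log units; beyond the scatter) and a 12-fold lower number from compound 1 to compound 3 (1.08 log units; beyond the scatter), with a 3.4-fold lower number from compound 2 to compound 3 (0.53 log units; beyond the scatter) separating the two replacements.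

Compound 4 `O=C(N1CCC(c2nc(-c3ccc4ccccc4n3)no2)CC1)N1CCCc2ccccc21` differs from compound 1 at the same carbonyl carbon: 1,2,3,4-tetrahydroquinolin-1-yl in place of (3,5-dimethyl-1,2-oxazol-4-yl)amino on a carbonyl carbon. The two measured steps at this position both bear on it, and both point downward, so a lower number is expected for compound 4 in this assay. The step is estimated to lie between the modest one seen for compound 2 and the large one seen for compound 3, as a 6.0-fold lower number from compound 1 to compound 4 (0.78 log units; beyond the scatter). Compound 4 is therefore expected to give about 500 nM in this assay, within a range from 150 nM to 1500 nM.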

Compound 4, half-maximal inhibitory concentration: 2300 nM
Compound 4: the middle estimate sits 4.6-fold (0.66 log units) below what was measured, and the stated range ends below it.
By their numbers in this assay, from the lowest: compound 3; then compound 2; then compounds 4 and 1 (each within the scatter of the next).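

At this carbonyl carbon, the change to 1,2,3,4-tetrahydroquinolin-1-yl barely registers in this assay (a 1.3-fold lower number from compound 1 to compound 4 (0.12 log units; within the scatter)), so a group with no hydrogen-bond donors or acceptors behaves here like the (3,5-dimethyl-1,2-oxazol-4-yl)amino group it replaces. Among these four compounds, the two groups bound to the carbonyl through nitrogen now stand at the high end, with no compound going against this: the replacements show a 2.7-fold higher number from compound 2 to compound 4 (0.44 log units; beyond the scatter) and a 9.2-fold higher number from compound 3 to compound 4 (0.96 log units; beyond the scatter). Nothing available explains this result.

The compounds shown leave open whether the atom bound to the carbonyl matters at all, or only the particular groups attached. A plain phenoxy group, a benzyloxy group or a piperidin-1-yl group would help separate these two readings.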